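Chloro in Place of Isopropyl on a Kynurenine Monooxygenase Inhibitor

A few compounds are considered here, and "the series" means these few. Any claim that something is new, unique, unknown or untested is made for them only; others in the source may bear on it.

Three compounds have been measured so far:
compound 1, `Nc1ccc(S(=O)(=O)Nc2nc(-c3cccc([N+](=O)[O-])c3)cs2)cc1`, giving 40 nM;
compound 2, `COc1ccc(S(=O)(=O)Nc2nc(-c3cccc([N+](=O)[O-])c3)cs2)cc1`, giving 51 nM;
compound 3, `CC(C)c1ccc(S(=O)(=O)Nc2nc(-c3cccc([N+](=O)[O-])c3)cs2)cc1`, giving 990 nM.

All three were tested in an assay on isolated protein for inhibition of kynurenine 3-monooxygenase (Rattus norvegicus); on this read-out higher numbers stand for weaker inhibition and lower numbers for stronger inhibition. Compound 3 carries the highest number of the three, and its nearest neighbour on the numbers is compound 2: a 19-fold higher number from compound 2 to compound 3 (1.29 log units; beyond the scatter). The gap to compound 1 is larger still: a 25-fold higher number from compound 1 to compound 3 (1.39 log units; beyond the scatter). Compound 1 and compound 2 lie close together, a 1.3-fold higher number from compound 1 to compound 2 (0.11 log units; within the scatter), so no order between them can be read.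

Compound 4, `O=[N+]([O-])c1cccc(-c2csc(NS(=O)(=O)c3ccc(Cl)cc3)n2)c1`, differs from compound 3 in one place: chloro in place of isopropyl on an aromatic carbon. The two steps that bear on this are the ones from compound 1 and compound 2 to compound 3, where a larger group took the place of a smaller one and the number rose sharply each time. Going by the values given here, the new change goes the other way, from isopropyl to a group of one heavy atom, and a step back toward the numbers of compound 1 and compound 2 is expected, though no measured pair contains chloro. The estimate for compound 4 is therefore 150 nM, with a range from 40 nM to 600 nM, which amounts to an expected step of a 6.6-fold lower number from compound 3 to compound 4 (0.82 log units; beyond the scatter).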

Compound 4, half-maximal inhibitory concentration: 84 nM
Compound 4: the middle estimate sits 1.8-fold (0.25 log units) above what was measured; the range from low to high includes it.
By their numbers in this assay, from the lowest: compounds 1, 2 and 4 (each within the scatter of the next, the first and the last beyond it); then compound 3.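

Replacing isopropyl with chloro, the change from 4-isopropylphenyl to 4-chlorophenyl, gives a large step in this assay (a 12-fold lower number from compound 3 to compound 4 (1.07 log units; beyond the scatter)), so compound 3 now stands apart from all three other compounds at this position, not just from those carrying amino and methoxy. Isopropyl and chloro both count no hydrogen-bond donors and no hydrogen-bond acceptors, so those counts cannot separate them, although they differ in heavy atoms, with chloro having fewer. Chloro cannot be ordered against methoxy (a 1.6-fold higher number from compound 2 to compound 4 (0.22 log units; within the scatter)), while the step from amino is modest (a 2.1-fold higher number from compound 1 to compound 4 (0.32 log units; beyond the scatter)), and no measurement at hand accounts for any of these steps.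

Isopropyl is the only carbon group here, so it remains open whether a methyl, an ethyl or a tert-butyl group would give a number near that of compound 4 or near that of compound 3. Fluoro and bromo would show whether chloro's result extends to other halogens, and a carboxylic acid would test a group quite unlike any of these four at the same place.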